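One Measured Number and a Large Swap Ahead

This account rests on a few compounds, and the source may have more. Where it says the series, first, only, none or still open, it means among the compounds named here.

Among the measured compounds shown here, in a functional assay on ID8 cells (Mus musculus) for antiproliferative activity (a higher number here means a weaker inhibitor, a lower number a stronger inhibitor), compound 1 `O=C(Nc1ccc(O)c2c(=O)cc(-c3ccccc3Cl)oc12)c1ccc(Cl)cc1` gives 5500 nM and is the only compound here with a number. Two relatives have no reported result: compound 2 `O=C(Nc1c(O)cc(O)c2c(=O)cc(-c3ccccc3Cl)oc12)c1ccc(Cl)cc1` stands as "not determined" (no result reported) and compound 3 `Cc1ccc(C(=O)Nc2c(O)cc(O)c3c(=O)cc(-c4ccccc4Cl)oc23)cc1` stands as "not determined" (no result reported) in this small set, so no comparison within it is possible.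

Compound 4 `C[C@@H](NC(=O)OC(C)(C)C)C(=O)Nc1ccc(O)c2c(=O)cc(-c3ccccc3Cl)oc12` has not been measured yet. It keeps the core of compound 1 but swaps the group on a carbonyl carbon whose other neighbour is an amide-type nitrogen. There, 1-((tert-butoxycarbonyl)amino)ethyl stands in place of 4-chlorophenyl 1-((tert-butoxycarbonyl)amino)ethyl in place of 4-chlorophenyl on a carbonyl carbon and so an aromatic ring gives way to a group with no ring and one defined stereocentre.

For the measured compounds named here, no measured step in this assay shows what a swap like this does, so the expectation is loose and rests on compound 1 at 5500 nM alone. The expected step of a 1.8-fold higher number from compound 1 to compound 4 (0.26 log units; within the scatter) is a modest weakening, and the swap is large, so the margin is wide on both sides. For compound 4 the estimated value is 10000 nM with an expected range from 3000 nM to 35000 nM in this measurement.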

Compound 4, half-maximal inhibitory concentration: 104000 nM
The estimate for compound 4 lay 10-fold (1.02 log units) below the measured number; measured number outside the range, above it.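

In this assay the group on a carbonyl carbon whose other neighbour is an amide-type nitrogen proves to matter: with the rest of the molecule unchanged, putting 1-((tert-butoxycarbonyl)amino)ethyl in place of 4-chlorophenyl gives a 19-fold higher number from compound 1 to compound 4 (1.28 log units; beyond the scatter) and so moves the number well beyond the usual scatter. Among the compounds shown here, this is the first measured pair to say anything about this position, since compounds 2 and 3 carry no number. Nothing available explains the weakening, and the swap removes a ring while adding a stereocentre, so no single feature can be singled out.

As far as these compounds go, whether the lost aromatic ring or the added tert-butoxycarbonyl part drives the step remains open. A free amine on the same ethyl group, or an unsubstituted phenyl ring in place of 4-chlorophenyl, would help to separate these changes.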